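The compounds below may be only part of what the source reports. "The series", "measured", "known", "first", "only" and "open" are said of these compounds alone.

Compound 1 `COc1cc(-c2nn(-c3cccc(NC(=O)c4ccc(Cl)c(C(F)(F)F)c4)c3)cc2-c2ccncc2)ccc1Cl` stands at the edge of what a functional assay on MDA-MB-468 cells (Homo sapiens) for inhibition, read by sulforhodamine B assay, with a stated time of 48 h (a lower number here means a stronger inhibitor of growth, a higher number a weaker inhibitor of growth), can report: compound 1 gives > 32500 nM, a limit of the assay rather than a number (the limit of > 32500 nM in this assay, at which 1 of the 3 values shown sits). Compound 2 `O=C(Nc1cccc(-n2cc(-c3ccncc3)c(-c3ccc(Cl)c(O)c3)n2)c1)Nc1cc(C(F)(F)F)cc(C(F)(F)F)c1` gives 2660 nM in this assay, and compound 3 `O=C(Nc1cccc(-n2cc(-c3ccncc3)c(-c3ccc(Cl)c(O)c3)n2)c1)Nc1ccc(Cl)c(C(F)(F)F)c1` gives 1750 nM. Compound 4 `COc1cc(-c2nn(-c3cccc(NC(=O)Nc4ccc(Cl)c(Cl)c4)c3)cc2-c2ccncc2)ccc1Cl` is not yet measured. It differs from compound 1 by (3,4-dichlorophenyl)amino in place of 4-chloro-3-(trifluoromethyl)phenyl on a carbonyl carbon. Because compound 1 shows only > 32500 nM, the size of the step cannot be read from these numbers; a move toward stronger growth inhibition, beyond the usual scatter, is expected, as compound 2 at 2660 nM and compound 3 at 1750 nM return numbers well within the assay range. A step of an at least 4.0-fold lower number from compound 1 to compound 4 (0.60 log units; beyond the scatter) is expected. Compound 4 is estimated at 8000 nM, within 2000 nM to 32000 nM.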

Compound 4, concentration for total growth inhibition: 2270 nM
The estimate for compound 4 lay 3.5-fold (0.55 log units) above the measured number; the range from low to high includes it.
By their numbers in this assay, from the lowest: compounds 3, 4 and 2 (each within the scatter of the next). At a limit, above all of these: compound 1.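

In this assay, (3,4-dichlorophenyl)amino in place of 4-chloro-3-(trifluoromethyl)phenyl on a carbonyl carbon gives an at least 14-fold lower number from compound 1 to compound 4 (1.15 log units; beyond the scatter). Within the data shown here, this is the first change at this position, and it brings the core of compound 1 into the measurable range. The true size of the step stays unknown, and the value of compound 1 is only a limit: the limit of > 32500 nM in this assay, at which 1 of the 4 values shown sits.

Still open, on these data alone, is whether the entering amino nitrogen or the chlorine in place of trifluoromethyl carries the step, since both arrive in one change. As far as these compounds go, how a morpholine or a carboxylic acid would read at this position also remains open.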